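Bromo for Methoxy on the Aryl Ring of Compound 1

The source may report more compounds than this note shows. Statements on the series, on what has been measured and on what is new or still open speak of the compounds shown alone.

Compound 1, `COc1ccc(/C(Cl)=C/C=C(\C#N)C(=O)c2c(C)[nH]c3ccccc23)cc1`, gives 63.1% in a functional assay for inhibition, with a stated time of 5 min, tested at 1 mM; a lower number here means less inhibition, a higher number more inhibition at the concentration tested (going by the name of the read-out).
Compound 2, `COc1ccc(/C(Cl)=C/C=C(\C#N)C(=O)c2c[nH]c3ccccc23)cc1`, gives 61.3% in this assay.
Compound 3, `COc1ccc(/C(Cl)=C/C=C(\C#N)C(=O)c2c(C)[nH]c3ccccc23)cc1OC`, gives 66.4% in this assay.

Among these three numbers compound 1 stands second highest. Its nearest neighbour is compound 2, with a number 1.8 percentage points lower from compound 1 to compound 2 (within the scatter), and its furthest is compound 3, with a number 3.3 percentage points higher from compound 1 to compound 3 (within the scatter); both steps lie within the scatter, so the three compounds cannot be told apart in this assay.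

Compound 4, `Cc1[nH]c2ccccc2c1C(=O)/C(C#N)=C/C=C(\Cl)c1ccc(Br)cc1`, has not yet been measured. It differs from compound 1 in one place: bromo in place of methoxy on an aromatic carbon. Neither measured step bears directly on this exchange. The step from compound 1 to compound 2 concerns the methyl on the core, and the step from compound 1 to compound 3 concerns an added methoxy; both were small and within the scatter. Nothing in the measured set shows that a change on this aryl ring moves the inhibition beyond the scatter, and nothing shows the opposite either.

Compound 4 is therefore expected to give about the same inhibition as compound 1, with a step of a number 2.1 percentage points lower from compound 1 to compound 4 (within the scatter) that stays within the scatter. The estimated value for compound 4 is 61%, in a range from 45% to 77%.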

Compound 4, a percentage reported as inhibition, at one concentration (the size of the read-out at that concentration, not a potency): 69.1%
Beside the measured number, compound 4's estimate is 8.1 percentage points below it; low and high end bracket the measured number.
By their numbers in this assay, from the lowest: compounds 2, 1, 3 and 4 (each within the scatter of the next).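

In this assay, exchanging the group on this aromatic carbon, para to a large group, gives a number 6 percentage points higher from compound 1 to compound 4 (within the scatter). Compounds 1, 2 and 3 all carry a methoxy at this place, so they could not show what happens when it leaves; compound 4 shows that inhibition at the concentration tested persists with a bromo there, and the change from 4-methoxyphenyl to 4-bromophenyl cannot be told apart from the scatter. No supporting measurement accompanies this result, so the data offer no explanation of why these two groups read alike.

As far as these compounds go, how an amine, a carboxylic acid or a longer alkoxy chain on this carbon would read remains open, as does whether any group here can move the inhibition beyond the scatter. Also open, from the compounds shown here alone, is whether the bromo would read the same on the core without the methyl, and, since the read-out comes from a single concentration, whether compound 1 and compound 4 would differ in potency.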